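Swapping the hydroxylated aryl for a methoxyphenyl

A few compounds are considered here, and "the series" means these few. Any claim that something is new, unique, unknown or untested is made for them only; others in the source may bear on it.

Measured so far:
compound 1, `Cc1c(C(=O)N/N=C\c2cc(O)ccc2O)oc2cccc(O)c12`, 95500 nM
compound 2, `Cc1c(C(=O)N/N=C\c2cccc(O)c2O)oc2cccc(O)c12`, 12200 nM

Both compounds were tested in a functional assay on PC-3 cells (Homo sapiens) for inhibition; on this read-out higher numbers stand for weaker inhibition and lower numbers for stronger inhibition. Among the measured compounds shown here, of the two numbers, compound 2 has the lowest, with compound 1 showing a 7.8-fold lower number from compound 1 to compound 2 (0.89 log units; beyond the scatter); this is the only measured step and it changes the aryl group that sits on a carbon with a double bond to nitrogen.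

Compound 3, `COc1cccc(/C=N\NC(=O)c2oc3cccc(O)c3c2C)c1`, has not been measured. It differs from compound 2 in that same position: 3-methoxyphenyl in place of 2,3-dihydroxyphenyl on a carbon with a double bond to nitrogen.

For the measured compounds named here, the one measured step bears on it only loosely: it shows that moving a hydroxyl around this aryl group shifts the number well beyond the scatter, so the aryl group matters, but no measured compound lacks hydroxyls there or carries a methoxy. With both hydroxyls gone and a methoxy entering, a step in either direction is possible; an increase in the number toward weaker inhibition is taken as the more likely outcome, expected as a 3.3-fold higher number from compound 2 to compound 3 (0.52 log units; beyond the scatter). Compound 3 is therefore estimated at 40000 nM, with a range from 8000 nM to 200000 nM.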

Compound 3, half-maximal inhibitory concentration: >= 40000 nM
Compound 3: a limit, no number (the forecaster's own chance of this, stated with the estimate: 30%); the middle value lies on the limit itself.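

Among the compounds shown here, until now, the only change at this position had moved a hydroxyl around the aryl group, so every compound carried two hydroxyls there; compound 3 is the first with none, and the first with a methoxy. In this assay, placing 3-methoxyphenyl instead of 2,3-dihydroxyphenyl on the carbon with a double bond to nitrogen gives an at least 3.2-fold higher number from compound 2 to compound 3 (0.51 log units; beyond the scatter), so this swap does not keep the stronger inhibition of compound 2 and the change is at least modest in size. The reading for compound 3 is a limit and not a number, which leaves its step from compound 1 unreadable and its true value unknown: the limit of >= 40000 nM in this assay, at which 1 of the 3 values shown sits.

The hydroxyls leave and the methoxy enters in a single step, and the compounds shown do not separate the share of each, nor do they show how a single hydroxyl at this place would compare. They also leave open what an amine, a carboxylic acid or a longer chain such as ethoxy on this aryl group would do to the number.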